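Compound 1 to compound 4: chloro for hydroxymethyl

The source may hold more compounds than are shown below. What is called first, only, known or untested is meant among the compounds shown, and "the series" means these compounds.

In a functional assay on MCF7 cells (Homo sapiens) for antiproliferative activity, read by MTT assay, with a stated time of 48 h (on this read-out lower numbers stand for stronger inhibition and higher numbers for weaker inhibition), compound 1 (`COc1cc(/C=C/C(C)=O)ccc1OCc1cn(-c2ccccc2CO)nn1`) gives 65800 nM. Among the measured compounds shown here, compound 3 (`COc1cc(/C=C/C(C)=O)ccc1OCc1cn(-c2ccc(C(F)(F)F)c(C(F)(F)F)c2)nn1`) gives 87400 nM, within the scatter of compound 1, and these are the only two true numbers in the set. Compound 2 (`COc1cc(/C=C/C(C)=O)ccc1OCc1cn(-c2ccc([N+](=O)[O-])cc2)nn1`) reads > 100000 nM, which is a limit of the assay and not a number.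

Compound 4 (`COc1cc(/C=C/C(C)=O)ccc1OCc1cn(-c2ccccc2Cl)nn1`) has chloro in place of hydroxymethyl on an aromatic carbon, ortho to a large group: chloro in place of hydroxymethyl on an aromatic carbon. For the measured compounds named here, the one measured step, an at least 1.5-fold higher number from compound 1 to compound 2 (0.18 log units; that floor lies within the scatter), replaces the whole 2-(hydroxymethyl)phenyl with 4-nitrophenyl, so it bears only loosely on this change. Its size is only a floor, set by the limit of > 100000 nM in this assay, at which 1 of the 3 values shown sits. Compound 3 also lacks the hydroxymethyl and still stays within the scatter of compound 1.

No step beyond the scatter is therefore expected in this assay. The estimated change is a 1.1-fold higher number from compound 1 to compound 4 (0.03 log units; within the scatter). For compound 4 the expected value is 70000 nM, with an estimated range of 35000 nM to 100000 nM.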

Compound 4, half-maximal inhibitory concentration: 2190 nM
Beside the measured number, compound 4's estimate is 32-fold (1.50 log units) above it; the measured number lies below the stated range.
By their numbers in this assay, from the lowest: compound 4; then compounds 1 and 3 (each within the scatter of the next). At a limit, above all of these: compound 2.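

Among the compounds shown here, on the aromatic carbon ortho to a large group, the choice of group carries real weight in this assay: chloro in place of hydroxymethyl gives a 30-fold lower number from compound 1 to compound 4 (1.48 log units; beyond the scatter) and is the first step beyond the scatter. Losing hydroxymethyl is not enough to give a low number, since compound 3, which also lacks it, gives 87400 nM in this assay. With 2-chlorophenyl in place of 4-nitrophenyl on the aromatic nitrogen, the change is an at least 45-fold lower number from compound 2 to compound 4 (1.65 log units; beyond the scatter) but serves only as a floor, compound 2 being at a limit of the assay and not a number: the limit of > 100000 nM in this assay, at which 1 of the 4 values shown sits.

As far as these compounds go, whether the low number belongs to chloro itself or would hold for bromo, methyl or aminomethyl at the same place remains open. So does the effect of moving chloro elsewhere on the six-membered aromatic ring.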